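This account rests on a few compounds, and the source may have more. Where it says the series, first, only, none or still open, it means among the compounds named here.

Compound 1 `COc1cccc(F)c1-c1cccc2nc(N)oc12`: > 20000 nM
Compound 2 `COc1ccc(Nc2nc3cccc(-c4c(F)cccc4OC)c3o2)cc1`: > 20000 nM
Compound 3 `CCOc1cccc(F)c1-c1cccc2nc(Nc3cc(OC)c(OC)c(OC)c3)oc12`: 10800 nM

Of the compounds shown here, three have so far been tested in an assay on BAF cells for inhibition of ribosomal protein S6 kinase alpha-2 (Mus musculus); a higher number here means a weaker inhibitor, a lower number a stronger inhibitor. For compound 1 the value > 20000 nM is a limit of the assay and not a number. For compound 2 the value > 20000 nM is likewise a limit. Compound 3 alone gives a number, 10800 nM, and so stands as the single readable point; the step that the two limits leave unreadable from compound 1 to compound 2 remains unreadable because of the limit of > 20000 nM in this assay, at which 2 of the 3 values shown sit. Compound 4 `COc1cc(Nc2nc3cccc(-c4ccccc4-c4cn[nH]c4)c3o2)cc(OC)c1OC` differs from compound 3 by a group of 11 heavy atoms (9 carbon, 2 nitrogen; one five-membered aromatic ring with 2 hetero atoms, one six-membered aromatic ring of carbon only) in place of a group of 10 heavy atoms (8 carbon, 1 oxygen, 1 fluorine; one six-membered aromatic ring of carbon only), on an aromatic carbon. Among the measured compounds shown here, no measured step bears on this change, so the step is expected to stay within the scatter, and compound 4 is estimated at 8000 nM (range 2000 nM to 20000 nM). The expected step is therefore a 1.4-fold lower number from compound 3 to compound 4 (0.13 log units; within the scatter).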

Compound 4, half-maximal inhibitory concentration: > 20000 nM
Compound 4: no number, only a limit; the forecaster's own chance of this, stated with the estimate: 40%; middle value at least 2.5-fold (0.39 log units) away from the limit.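

In this assay compound 4 gives > 20000 nM, which is a limit of the assay and not a number. On this aromatic carbon, the exchange of the 2-ethoxy-6-fluorophenyl group for the group with a five-membered aromatic ring gives an at least 1.8-fold higher number from compound 3 to compound 4 (0.26 log units; that floor lies within the scatter), so the change shows no gain in this assay. Its full size cannot be fixed because the read-out ends at a limit: the limit of > 20000 nM in this assay, at which 3 of the 4 values shown sit.

As far as these compounds go, it remains open whether a propoxy chain in place of the ethoxy group would lower the number. Also open, from the compounds shown here alone, is what an amine or a carboxylic acid on the phenyl ring at this carbon would do.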